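A few compounds are considered here, and "the series" means these few. Any claim that something is new, unique, unknown or untested is made for them only; others in the source may bear on it.

Compound 1 `NNc1nonc1/C(=N/O)Nc1ccc(F)c(Br)c1` carries an amino group on a nitrogen on an aromatic ring of the shared core. For the measured compounds named here, in an assay on HeLa cells for inhibition of Indoleamine 2,3-dioxygenase 1 (Homo sapiens), read by spectrophotometry, with a stated time of 24 h (on this read-out lower numbers stand for an effect already at smaller amounts and higher numbers for an effect only at larger amounts of compound), compound 1 gives 556 nM, the highest of the three numbers measured so far. Compound 2 `O=S1(=O)CC(Nc2nonc2/C(=N/O)Nc2ccc(F)c(Br)c2)C1` gives 59 nM, and compound 3 `NS(=O)(=O)CCNc1nonc1/C(=N/O)Nc1ccc(F)c(Br)c1` gives 11 nM. The change leading to compound 4 `C#CCNS(=O)(=O)CCNc1nonc1/C(=N/O)Nc1ccc(F)c(Br)c1` is 2-(propargylsulfamoyl)ethyl in place of amino on a nitrogen on an aromatic ring. The measured steps that bear on this are a 9.4-fold lower number from compound 1 to compound 2 (0.97 log units; beyond the scatter) and a 51-fold lower number from compound 1 to compound 3 (1.70 log units; beyond the scatter): both replacements on this nitrogen lowered the number, and the 2-sulfamoylethyl group of compound 3 is contained within the group entering compound 4. For compound 4 a step of comparable size downward is therefore expected, a 37-fold lower number from compound 1 to compound 4 (1.57 log units; beyond the scatter). Compound 4 is estimated at 15 nM, within a range from 4 nM to 60 nM.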

Compound 4, half-maximal effective concentration: 33 nM
The estimate for compound 4 lay 2.2-fold (0.34 log units) below the measured number; low and high end bracket the measured number.
By their numbers in this assay, from the lowest: compound 3; then compounds 4 and 2 (each within the scatter of the next); then compound 1.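

The 2-sulfamoylethyl chain tolerates a substituent and still keeps much of its gain over the amino group, with a 17-fold lower number from compound 1 to compound 4 (1.23 log units; beyond the scatter). The sulfonamide nitrogen is nevertheless sensitive to change, as propargyl in place of hydrogen gives a 3.0-fold higher number from compound 3 to compound 4 (0.48 log units; beyond the scatter). The open propargyl chain and the four-membered ring cannot be told apart, since a 1.8-fold lower number from compound 2 to compound 4 (0.25 log units; within the scatter).

No measurement here explains these differences. From the compounds shown here alone, whether a methyl group or a saturated propyl chain on the sulfonamide nitrogen would behave like propargyl remains open.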